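Carbonyl substituent change from compound 2 to compound 3

The source may report more compounds than this note shows. Statements on the series, on what has been measured and on what is new or still open speak of the compounds shown alone.

Of the compounds shown here, two of the shared core have so far been measured in an assay on membranes from CHO cells for displacement of a labelled ligand from adenosine receptor A1 (Homo sapiens), read by scintillation counting, with a stated time of 60 min, tested at 1 uM; on this read-out lower numbers stand for less inhibition and higher numbers for more inhibition at the one concentration tested (going by the name of the read-out). Compound 1 `CC1=C(C(=O)OCc2ccccc2)C(c2ccco2)NC(=O)N1` gives 36%. Compound 2 `CC1=C(C(=O)SC(C)C)C(c2ccco2)NC(=O)N1` gives 5%, the lowest of the two numbers, and compound 1 stands higher by a gap beyond the usual scatter. Compound 3 `CC1=C(C(=O)OC2CCCC2)C(c2ccco2)NC(=O)N1` has not yet been measured. Against compound 2 it carries the change (cyclopentyloxy in place of isopropylsulfanyl on a carbonyl carbon). Among the compounds with values here, no step between two measured compounds isolates this change, so its size cannot be read off directly. Compound 3 is expected to land nearer compound 1 than compound 2, because compound 1, which also carries an oxygen rather than a sulfur on the carbonyl carbon, gives 36% in this assay. Compound 3 is expected to give 22% in this assay, within a range from 5% to 40%. An upward step of a number 17 percentage points higher from compound 2 to compound 3 (beyond the scatter) is expected, likely beyond the scatter.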

Compound 3, a percentage reported as inhibition, at one concentration (the size of the read-out at that concentration, not a potency): 1%
Estimate against measurement, compound 3: 21 percentage points above; the whole stated range lies above it.
By their numbers in this assay, from the lowest: compounds 3 and 2 (each within the scatter of the next); then compound 1.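

In this assay, cyclopentyloxy in place of isopropylsulfanyl on a carbonyl carbon gives a number 4 percentage points lower from compound 2 to compound 3 (within the scatter), so an oxygen in place of the sulfur at this position does not by itself bring the read-out up to the level of compound 1. The larger difference lies in the group on the oxygen: cyclopentyl in place of benzyl on an oxygen next to a carbonyl group gives a number 35 percentage points lower from compound 1 to compound 3 (beyond the scatter), which sets compound 1 apart from the other two compounds. Nothing available explains this difference.

On these data alone, it remains open whether the benzyl group's aromatic ring or its single carbon link counts for more, which a phenyl or a phenethyl group on the oxygen would help to separate. Also open, as far as these compounds go, is whether a benzylamino group on the carbonyl carbon would hold the level of compound 1.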